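The compounds below may be only part of what the source reports. "The series", "measured", "known", "first", "only" and "open" are said of these compounds alone.

Going by the values given here, in an ADME assay on CCRF-CEM cells (Homo sapiens) for cytotoxicity, with a stated time of 4 days (a higher number here means that more compound is tolerated, a lower number that less compound is tolerated), compound 2 `Cc1cn([C@@H]2O[C@H](CO[Si](C)(C)C(C)(C)C)[C@@]3(OS(=O)(=O)C=C3N)[C@H]2O[Si](C)(C)C(C)(C)C)c(=O)n(C(=O)CCCBr)c1=O` gives 11000 nM, the only actual number so far. Compound 1 `COC(=O)n1c(=O)c(C)cn([C@@H]2O[C@H](CO[Si](C)(C)C(C)(C)C)[C@@]3(OS(=O)(=O)C=C3N)[C@H]2O[Si](C)(C)C(C)(C)C)c1=O` reads > 100000 nM, which is a limit of the assay and not a number. Compound 3 `COC(=O)CCCC(=O)n1c(=O)c(C)cn([C@@H]2O[C@H](CO[Si](C)(C)C(C)(C)C)[C@@]3(OS(=O)(=O)C=C3N)[C@H]2O[Si](C)(C)C(C)(C)C)c1=O` differs from compound 2 by methoxycarbonyl in place of bromo on a saturated chain carbon, three bonds along the chain from a carbonyl carbon: methoxycarbonyl in place of bromo on a saturated chain carbon. Among the compounds with values here, the one measured step bearing on this is an at least 9.0-fold lower number from compound 1 to compound 2 (0.95 log units; beyond the scatter), with 3-bromopropyl in place of methoxy on a carbonyl carbon. As compound 3 loses that bromo, a partial return towards less tolerated compound is not implied; a higher number is expected instead, and the expected step is a 3.6-fold higher number from compound 2 to compound 3 (0.56 log units; beyond the scatter). For compound 3 the estimated value is 40000 nM, within a range of 14000 nM to 100000 nM.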

Compound 3, half-maximal cytotoxic concentration: 9900 nM
Beside the measured number, compound 3's estimate is 4.0-fold (0.61 log units) above it; measured number below the stated range.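

Methoxycarbonyl in place of bromo gives a 1.1-fold lower number from compound 2 to compound 3 (0.05 log units; within the scatter), so the bromo is not required for the lower number. The 3-(methoxycarbonyl)propyl group in place of methoxy on a carbonyl carbon gives an at least 10-fold lower number from compound 1 to compound 3 (1.00 log units; beyond the scatter), so compound 2 and compound 3 both stand apart from compound 1. That step is open-ended because compound 1 reads a limit and not a number: the limit of > 100000 nM in this assay, at which 1 of the 3 values shown sits. From the compounds shown here alone, whether a carboxylic acid or an amine in that place, or a longer chain, would keep the number at this level stays open.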